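This account rests on a few compounds, and the source may have more. Where it says the series, first, only, none or still open, it means among the compounds named here.

In a functional assay on A-375 cells (Homo sapiens) for cytotoxicity, read by MTT assay, with a stated time of 72 h, tested at 10 uM (on this read-out higher numbers stand for more inhibition of growth at the one concentration tested and lower numbers for less inhibition of growth), compound 1 `N/C(=N\NC(=S)N1CCCCCC1)c1ccccn1` gives 86.5%. Compound 2 `N/C(=N\NC(=S)N1CCCCC1)c1ccccn1` has a core that differs from that of compound 1 in a way that is not broken down here. In this assay compound 2 gives 85.8%, a number within the scatter of that of compound 1, so no order between the two can be read from it. Compound 3 `Cc1ccnc(/C(N)=N/NC(=S)N2CCCCCC2)c1` carries a methyl in place of hydrogen on an aromatic carbon of the core of compound 1, the change being (methyl in place of hydrogen on an aromatic carbon), and in this assay compound 3 gives 70.6%. The resulting step, a number 15.9 percentage points lower from compound 1 to compound 3 (beyond the scatter), is beyond the scatter and is the only step between singly differing measured compounds shown here.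

Compound 4 `Cc1ccnc(/C(N)=N/NC(=S)N2CCCCC2)c1` has not yet been measured in this assay. It stands to compound 2 exactly as compound 3 stands to compound 1: the change is methyl in place of hydrogen on an aromatic carbon, the same change made from compound 1 to compound 3, and it occurs twice among the four compounds. Because the step of a number 15.9 percentage points lower from compound 1 to compound 3 (beyond the scatter) was modest and beyond the scatter, compound 4 is expected to fall short of compound 2 by a step of about a number 15.8 percentage points lower from compound 2 to compound 4 (beyond the scatter), a step of the same kind. Compound 4 is therefore estimated to give 70% in this assay, with a likely range from 58% to 81%.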

Compound 4, percent growth inhibition at one concentration: 81.2%
Beside the measured number, compound 4's estimate is 11.2 percentage points below it; measured number outside the range, above it.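

In this assay, methyl in place of hydrogen on an aromatic carbon gives a number 4.6 percentage points lower from compound 2 to compound 4 (within the scatter), so on this core the read-out cannot put the two compounds in order. Set beside the earlier step, the change cannot be said to act differently on the two cores: the same change on two cores in this assay, a number 15.9 percentage points lower (beyond the scatter) from compound 1 to compound 3 and a number 4.6 percentage points lower (within the scatter) from compound 2 to compound 4, 11.3 percentage points apart, within the scatter of two such steps. Among these compounds, this shows that the two steps could share one size, but it does not show that the change carries over with a fixed size, since only one of the two steps lies beyond the scatter and two pairs are a thin basis for any rule across this series.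

The compounds shown leave open whether a group other than methyl at the same place opposite the ring nitrogen, such as a methoxy group, a longer chain, an amine or a carboxylic acid, would keep the growth inhibition of the parent compounds, and how a methyl would read at other places on the same ring. They also leave open whether the picture would hold across a range of concentrations, as every number here comes from a single concentration on one cell line.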